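This account rests on a few compounds, and the source may have more. Where it says the series, first, only, none or still open, it means among the compounds named here.

Working notes on the series

Compound 1 `CC(C)(C)c1ccc(CN(C(=O)CN(Cc2c(F)c(F)c(F)c(F)c2F)S(=O)(=O)c2ccc(F)cc2)c2ccc(C(=O)NO)cc2)cc1` gives 190 nM in an assay on Sf9 cells for inhibition of protein deacetylase HDAC6 (Homo sapiens), read by mobility shift assay; on this read-out lower numbers stand for stronger inhibition and higher numbers for weaker inhibition. Compound 2 `O=C(NO)c1ccc(N(Cc2ccc(C(F)(F)F)cc2)C(=O)CN(Cc2c(F)c(F)c(F)c(F)c2F)S(=O)(=O)c2ccc(F)cc2)cc1` gives 86 nM in this assay. Within the data shown here, the one step measured so far, a 2.2-fold lower number from compound 1 to compound 2 (0.34 log units; beyond the scatter), changes the group on the aromatic ring of the benzyl bound to the amide nitrogen. Compound 1 therefore stands at the highest of the two numbers measured in this assay, with compound 2 the nearer and only neighbour.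

Compound 3 `CC(C)(C)c1ccc(CN(C(=O)CN(Cc2ccccc2C(F)(F)F)S(=O)(=O)c2ccc(F)cc2)c2ccc(C(=O)NO)cc2)cc1` differs from compound 1 at another place: 2-(trifluoromethyl)phenyl in place of 2,3,4,5,6-pentafluorophenyl on a saturated chain carbon bound to a sulfonamide nitrogen. Among the measured compounds shown here, no measured step touches this benzyl on the sulfonamide nitrogen, so the one step known, a 2.2-fold lower number from compound 1 to compound 2 (0.34 log units; beyond the scatter), bears on it only indirectly, as a sign that a change on a pendant benzyl moves the number modestly at most. The change from compound 1 to compound 3 is therefore expected to give a step of no change at the digits printed from compound 1 to compound 3 (within the scatter), no larger than the scatter in either direction. For compound 3 the estimated value in this assay is 190 nM, with a range from 60 nM to 600 nM.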

Compound 3, half-maximal inhibitory concentration: 230 nM
For compound 3 the middle estimate is 1.2-fold (0.08 log units) below the measured one; measured number inside the range.
By their numbers in this assay, from the lowest: compound 2; then compounds 1 and 3 (each within the scatter of the next).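

The benzyl on the sulfonamide nitrogen now has its first measured change: in this assay there is a 1.2-fold higher number from compound 1 to compound 3 (0.08 log units; within the scatter). At this place on the core of compound 1, 2,3,4,5,6-pentafluorobenzyl and 2-(trifluoromethyl)benzyl therefore cannot be told apart, and the full set of ring fluorines is not needed to hold a number of this size. No measurement on hand accounts for the two groups reading alike.

From the compounds shown here alone, whether 2-(trifluoromethyl)benzyl would read the same in a compound that also carries the trifluoromethyl group of compound 2 remains open, so the two changes cannot yet be treated as independent. Also open, going by these compounds, is how far this place tolerates groups of a different kind, such as an unsubstituted benzyl, a pyridylmethyl, a plain methyl or a chain ending in an amine or a carboxylic acid, as the two groups compared here are both fluorinated benzyls.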